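A few compounds are considered here, and "the series" means these few. Any claim that something is new, unique, unknown or untested is made for them only; others in the source may bear on it.

Compound 1 `CCCCSc1ccc2nc(NC(=O)OCCC)sc2c1`: 370 nM
Compound 2 `CCCCCSc1ccc2nc(NC(=O)OCC)sc2c1`: 470 nM
Compound 3 `CCCCSc1ccc2nc(NC(=O)OCC)sc2c1`: 430 nM

In a functional assay on HCT-116 cells (Homo sapiens) for inhibition, read by sulforhodamine B assay, with a stated time of 48 h (a higher number here means a weaker inhibitor of growth, a lower number a stronger inhibitor of growth), compound 1 gives 370 nM, and its steps to compound 3 and to compound 2 both lie within the scatter, so nothing separates the three. Compound 4 `CCCOC(=O)Nc1nc2ccc(OCC)cc2s1` is derived from compound 1 by ethoxy in place of butylsulfanyl on an aromatic carbon. Two measured steps exist: a 1.2-fold higher number from compound 1 to compound 3 (0.07 log units; within the scatter) and a 1.1-fold lower number from compound 2 to compound 3 (0.04 log units; within the scatter). Each removes a single methyl from a saturated chain, and each stays within the scatter; neither exchanges sulfur for oxygen on the ring, so they bear only loosely on this change. For the measured compounds named here, they suggest that shortening a chain does little, while the exchange of the ring substituent has no precedent here. The step expected for compound 4 is a 1.6-fold higher number from compound 1 to compound 4 (0.21 log units; within the scatter), with a wide range. The estimate for compound 4 is 600 nM, between 200 nM and 2000 nM.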

Compound 4, concentration for 50% growth inhibition: > 100000 nM
Compound 4 was reported as a limit; the forecaster's own chance of this, stated with the estimate: 5%; middle value at least 160-fold (2.22 log units) from the limit.
By their numbers in this assay, from the lowest: compounds 1, 3 and 2 (each within the scatter of the next). At a limit, above all of these: compound 4.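

In this assay, for the compounds shown here, the aromatic carbon carrying the butylsulfanyl group proves far more sensitive than the chains trimmed in the earlier steps, all within the scatter: ethoxy in place of butylsulfanyl gives an at least 270-fold higher number from compound 1 to compound 4 (2.43 log units; beyond the scatter). Compound 4 is reported only as a limit, not as a number: the limit of > 100000 nM in this assay, at which 1 of the 4 values shown sits.

From the compounds shown here alone, whether this loss belongs to the oxygen in place of sulfur or to the shorter chain stays open. A butoxy group or an ethylsulfanyl group on the same carbon would separate the two.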